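The compounds below may be only part of what the source reports. "The series", "measured", "known", "first", "only" and "open" are said of these compounds alone.

Measured compounds:
compound 1, `COc1ncc(-c2ccc3c(c2)N(c2ccc(C)cc2)C(=O)CO3)cc1NS(=O)(=O)c1ccc(F)cc1`: 22700 nM
compound 2, `O=C1COc2ccc(-c3cccc(NS(=O)(=O)c4ccc(F)cc4)c3)cc2N1c1ccccc1`: > 40000 nM

In a functional assay on HCT-116 cells (Homo sapiens) for antiproliferative activity, read by MTT assay, with a stated time of 72 h (a higher number here means a weaker inhibitor, a lower number a stronger inhibitor), compound 1 gives 22700 nM. For compound 2 the result is a limit of the assay, not a number: in this assay compound 2 gives > 40000 nM. Compound 2 thus stands at the limit of > 40000 nM in this assay, at which 1 of the 2 values shown sits, the edge of what the measurement can report. Compound 3, `O=C1COc2ccc(-c3cccc(NS(=O)(=O)c4ccc(F)cc4)c3)cc2N1C1CCCCC1`, has not yet been measured. It differs from compound 2 in one place: cyclohexyl in place of phenyl on an amide-type nitrogen in a ring. Among the compounds shown there is no measured pair that makes this same exchange, so the size of the step can only be guessed. Compound 2 stands at the limit of > 40000 nM in this assay, at which 1 of the 2 values shown sits, and no step beyond the usual scatter in this assay is expected in either direction. Compound 3 is estimated at 45000 nM, with a range from 15000 nM to 150000 nM. The step this estimate means is a step that the limit leaves unreadable from compound 2 to compound 3, and a result reported only as a limit is considered likely.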

Compound 3, half-maximal inhibitory concentration: 18300 nM
For compound 3 the middle estimate is 2.5-fold (0.39 log units) above the measured one; low and high end bracket the measured number.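

In this assay, putting cyclohexyl in place of phenyl on the amide-type nitrogen in a ring gives an at least 2.1-fold lower number from compound 2 to compound 3 (0.33 log units; beyond the scatter). Within the data shown here, this is the first sign that the group at this position affects the read-out: the two groups have the same count of heavy atoms, neither has a hydrogen-bond donor or acceptor, and they differ in that the phenyl ring is aromatic and the cyclohexyl ring is not. Only a minimum size can be read for this step, since one of its ends is a limit of the assay and not a number: the limit of > 40000 nM in this assay, at which 1 of the 3 values shown sits.

On these data alone, it remains open whether other groups on this nitrogen, such as a benzyl group or a chain ending in an amine, would lower the number further. The compounds shown also do not reveal why the exchange lowers the number.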